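The source may hold more compounds than are shown below. What is called first, only, known or untested is meant among the compounds shown, and "the series" means these compounds.

Compound 1, whose structure is `COc1ccc(/C=C/C(=O)/C=C/c2ccc(OCc3cn(CCCCCOc4cc(=O)oc5ccccc45)nn3)c(OC)c2)cc1`, was tested in a functional assay on PC-3 cells (Homo sapiens) for inhibition, read by sulforhodamine B assay, with a stated time of 48 h, tested at 50 uM; a lower number here means less inhibition of growth, a higher number more inhibition of growth at the concentration tested; there compound 1 is reported as "not active" (no number reported), so no single number fixes where compound 1 stands, only that its growth inhibition was judged too small to report. A related compound, compound 2 with the structure `COc1ccc(/C=C/C(=O)/C=C/c2ccc(OCc3cn(CCOc4cc(=O)oc5ccccc45)nn3)c(OC)c2)cc1`, which carries a shorter chain between the triazole and the coumarin part of the shared core, gives 15% in this assay. Both results therefore sit at the weak end of what this measurement can show. Compound 3, with the structure `COc1cccc(/C=C/C(=O)/C=C/c2ccc(OCc3cn(CCCCCOc4cc(=O)oc5ccccc45)nn3)c(OC)c2)c1`, has not been measured. It differs from compound 1 in one place: 3-methoxyphenyl in place of 4-methoxyphenyl on a double-bonded chain carbon bound to a double-bonded chain carbon. The rest of compound 3, including the long chain and the coumarin end, is identical to compound 1. Nothing measured here speaks to what moving the methoxy group on this ring does, so the expectation is for no step beyond the usual scatter in this assay. For compound 3 the growth inhibition is estimated at 10%, with a range from 0% to 30%.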

Compound 3, percent growth inhibition at one concentration: "not active" (no number reported)
Compound 3: no number reported, so the estimate cannot be set against anything.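

In this assay neither compound 1 nor compound 3 has a number, so no step can be read for the change from 4-methoxyphenyl to 3-methoxyphenyl. From the compounds shown here alone, whether moving the methoxy group alters growth inhibition at all, and by how much, stays open. No measurement at hand offers an explanation for either result.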